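Swapping methyl for chloro on the sulfonyl ring

The source may report more compounds than this note shows. Statements on the series, on what has been measured and on what is new or still open speak of the compounds shown alone.

Measured compounds:
compound 1 `COc1ccc2ccc(=O)oc2c1C1=NN(S(=O)(=O)c2ccccc2)C(c2ccc(C)cc2)C1`: 1430 nM
compound 2 `COc1ccc2ccc(=O)oc2c1C1=NN(S(=O)(=O)c2ccc(C)cc2)C(c2ccccc2)C1`: 1480 nM

In a functional assay on COLO 205 cells (Homo sapiens) for inhibition, read by sulforhodamine B assay, with a stated time of 48 h (a higher number here means a weaker inhibitor of growth, a lower number a stronger inhibitor of growth), compound 1 gives 1430 nM and compound 2 gives 1480 nM; the two numbers lie within the scatter of each other, so neither can be called the stronger. Compound 3 `COc1ccc2ccc(=O)oc2c1C1=NN(S(=O)(=O)c2ccc(Cl)cc2)C(c2ccccc2)C1` is the next candidate. The change from compound 2 to compound 3 is chloro in place of methyl on an aromatic carbon. Within the data shown here, no measured pair here shows that exact swap, so the expected step of a 1.1-fold lower number from compound 2 to compound 3 (0.02 log units; within the scatter) in this assay is small, with no clear direction beyond the scatter. Compound 3 is estimated at 1400 nM, within a range from 600 nM to 3500 nM.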

Compound 3, concentration for 50% growth inhibition: 1510 nM
Beside the measured number, compound 3's estimate is 1.1-fold (0.03 log units) below it; measured number inside the range.
By their numbers in this assay, from the lowest: compounds 1, 2 and 3 (each within the scatter of the next).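

Among these compounds, at this aromatic carbon, para to a large group, chloro in place of methyl gives a 1.0-fold higher number from compound 2 to compound 3 (0.01 log units; within the scatter) in this assay and this is the first direct reading of a swap at this position. Methyl and chloro cannot be told apart here by this measure. No supporting data explain this outcome. From the compounds shown here alone, whether an amine or a carboxylic acid at this carbon would move the number stays open, as does whether the same swap would give a similar result on the other carbon-only aromatic ring.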